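This account rests on a few compounds, and the source may have more. Where it says the series, first, only, none or still open, it means among the compounds named here.

Compound 2 `O=C(NO)c1ccc(NCc2nc(-c3cccnc3)nn2-c2ccccc2)cc1` carries a hydroxamic acid and a pyridin-3-yl group on its shared core. In an assay on Sf9 cells for inhibition of protein deacetylase HDAC6 (Homo sapiens), read by fluorescence, with a stated time of 40 min, tested at 100 nM (a lower number here means less inhibition, a higher number more inhibition at the concentration tested (going by the name of the read-out)), compound 2 gives 57.7%. Among the three compounds measured, this places compound 2 close to compound 1 `O=C(NO)c1ccc(NCc2nc(-c3ccccc3)nn2-c2ccccc2Cl)cc1`, which in this assay gives 64.6%, a number that differs from compound 2 only within the usual scatter, so the two cannot be told apart. Compound 3 `O=C(O)c1ccc(NCc2nc(-c3ccccc3)nn2-c2ccccc2)cc1`, in which a carboxylic acid takes the place of the hydroxamic acid, gives -0.4% in this assay, far below both and well beyond the scatter.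

Compound 4 `O=C(NO)c1ccc(NCc2nc(-c3ccc(Cl)cc3)nn2-c2ccccc2)cc1` has not been measured. It differs from compound 2 in one place: 4-chlorophenyl in place of pyridin-3-yl on an aromatic carbon. For the measured compounds named here, no measured pair shows this exact change. Because compound 1 gives 64.6% with a phenyl group at this same position, a step near zero or a small rise is expected in this assay, so the step from compound 2 to compound 4 is estimated at a number 4.3 percentage points higher from compound 2 to compound 4 (within the scatter). Compound 4 is therefore expected to give about 62%, within a range of 45% to 78%.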

Compound 4, a percentage reported as inhibition, at one concentration (the size of the read-out at that concentration, not a potency): 67.2%
Compound 4: middle estimate off by 5.2 percentage points, on the low side, and the stated range covers the measured number.
By their numbers in this assay, from the lowest: compound 3; then compounds 2, 1 and 4 (each within the scatter of the next).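

Read directly at the aromatic carbon between two ring nitrogen atoms, 4-chlorophenyl in place of pyridin-3-yl gives a number 9.5 percentage points higher from compound 2 to compound 4 (within the scatter) in this assay, so this exchange leaves no step that can be told from scatter. For the compounds shown here, it is the first direct reading of a change at this position, and it shows that the ring nitrogen of pyridin-3-yl, with its hydrogen-bond acceptor, can give way to a ring of carbon only that bears chlorine while compound 4 stays level with compound 2. Nothing given here accounts for the size of this step.

The compounds shown leave open how a plain phenyl, a methoxy group or fluorine in place of the chlorine would read on this same scaffold. They also leave open whether an open chain or an amine at this position would hold the number.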